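Replacing a dichlorophenyl sulfonamide with a methylphenyl one

The source may hold more compounds than are shown below. What is called first, only, known or untested is meant among the compounds shown, and "the series" means these compounds.

Compound 2 `O=S(=O)(Nc1ccc(-c2nc3ccccc3o2)cc1)c1ccc(Cl)c(Cl)c1` gives 25000 nM in an assay on cells for inhibition of HSP60/HSP10 (Homo sapiens), with a stated time of 60 min; a lower number here means a stronger inhibitor, a higher number a weaker inhibitor. Among the two measured compounds it holds the lowest number; compound 1 `O=S(=O)(Nc1ccc(-c2nc3ccccc3o2)cc1)c1cccc(Cl)c1` gives 54000 nM in this assay, and the step of a 2.2-fold lower number from compound 1 to compound 2 (0.33 log units; beyond the scatter) separates them, this being the only step recorded. Compound 3 `Cc1cccc(S(=O)(=O)Nc2ccc(-c3nc4ccccc4o3)cc2)c1` differs from compound 2 by 3-methylphenyl in place of 3,4-dichlorophenyl on a sulfonyl sulfur. Among the compounds with values here, the one measured step bears on this change only in part: it came from adding a chloro to an aromatic carbon, whereas compound 3 removes both chlorines of compound 2 while bringing in a methyl, for which no measured comparison exists. Taking the measured gain as something likely to be given back, a modest move toward a higher number in this assay is expected, about the size of the recorded step run backwards, though the methyl leaves this uncertain. Compound 3 is therefore estimated at 60000 nM (range 25000 nM to 150000 nM), with the step of a 2.4-fold higher number from compound 2 to compound 3 (0.38 log units; beyond the scatter) being what is expected.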

Compound 3, half-maximal inhibitory concentration: > 100000 nM
Compound 3: no number, only a limit (the forecaster's own chance of this, stated with the estimate: 20%); middle value at least 1.6-fold (0.22 log units) from the limit.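

In this assay compound 3 gives no number, only a limit: the limit of > 100000 nM in this assay, at which 1 of the 3 values shown sits. At this place on the sulfonyl sulfur, 3-methylphenyl in place of 3,4-dichlorophenyl brings an at least 4.0-fold higher number from compound 2 to compound 3 (0.60 log units; beyond the scatter), so a methyl does not hold the level reached with the two chlorines. Methyl in place of chloro on an aromatic carbon brings an at least 1.8-fold higher number from compound 1 to compound 3 (0.26 log units; that floor lies within the scatter), so this pair alone gives no firm order, and the chloro cannot yet be said to outperform the methyl at that carbon.

On these data alone, the true size of both steps stays open, since compound 3 has only a limit. Also open, as far as these compounds go, is whether a bromo, a methoxy, an amine or a carboxylic acid on this ring would give a lower number than the chlorines do in this assay.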